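Piperidin-1-yl for 4-methylpiperazin-1-yl on compound 1

A few compounds are considered here, and "the series" means these few. Any claim that something is new, unique, unknown or untested is made for them only; others in the source may bear on it.

Measured so far:
- compound 1 (`Cc1cc(NCCN2CCN(C)CC2)nc2ccc(NC(=O)c3ccc(Cl)c(Cl)c3)cc12`) gives 1700 nM
- compound 2 (`CCN1CCN(c2cc(C)c3cc(NC(=O)c4cc5ccccc5[nH]4)ccc3n2)CC1`) gives 2950 nM

Both values come from a functional assay on MCF7 cells (Homo sapiens) for antiproliferative activity, read by MTT assay, with a stated time of 72 h (a lower number here means a stronger inhibitor, a higher number a weaker inhibitor), and lie within the scatter of each other, so compound 1 has no separate standing on these two numbers.

Compound 3 (`Cc1cc(NCCN2CCCCC2)nc2ccc(NC(=O)c3ccc(Cl)c(Cl)c3)cc12`) has not yet been measured. It differs from compound 1 in a single place (piperidin-1-yl in place of 4-methylpiperazin-1-yl on a saturated chain carbon, two bonds along the chain from a nitrogen on an aromatic ring), and the rest of the structure stays the same. Within the data shown here, no measured pair carries this change, so the data give no direct size for it. In this assay the expected 1.1-fold lower number from compound 1 to compound 3 (0.05 log units; within the scatter) stays within the scatter, and no direction is claimed for it. Among the measured compounds shown here, this expectation rests on compound 1 at 1700 nM as the only measured compound sharing everything outside the changed group. Compound 3 is estimated at 1500 nM with an expected range (550 nM to 4200 nM).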

Compound 3, half-maximal inhibitory concentration in the MCF7 assay: 1190 nM
For compound 3 the middle estimate is 1.3-fold (0.10 log units) above the measured one; measured number inside the range.
By their numbers in the MCF7 assay, from the lowest: compounds 3, 1 and 2 (each within the scatter of the next, the first and the last beyond it).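

In the MCF7 assay, piperidin-1-yl in place of 4-methylpiperazin-1-yl gives a 1.4-fold lower number from compound 1 to compound 3 (0.15 log units; within the scatter), so on this saturated chain carbon the change of ring leaves no readable difference in the cell result. In a physicochemical assay for lipophilicity, at pH 7.4 (a higher number here means a more lipophilic compound, a lower number a more polar compound), compound 1 gives 1.73 and compound 3 gives 2.72, and the same change gives a number 0.99 log units higher from compound 1 to compound 3 (beyond the scatter), which provides the first measured size for this change and separates the pair clearly. The pair thus reads alike in the cell assay while differing in lipophilicity: the measured distribution coefficient of compound 1, 1.73, and of compound 3, 2.72, a number 0.99 log units higher (beyond the scatter)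

Still open, from the compounds shown here alone, is whether a morpholin-4-yl or dimethylamino group, or a longer chain, at this place would also stay within the scatter in the MCF7 assay. Going by these compounds, compound 2 differs from this pair in more than one place, so whether the step carries over to another amide group also remains open.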